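Trimming the amide cap of a strong aldosterone synthase inhibitor

A few compounds are considered here, and "the series" means these few. Any claim that something is new, unique, unknown or untested is made for them only; others in the source may bear on it.

Compound 1 `Cc1cc(Cl)ccc1C(=O)N(C)c1cccnc1` is a small tertiary amide. In an assay on cells for inhibition of cytochrome P450 11B2, mitochondrial (Homo sapiens), read by HTRF (a lower number here means a stronger inhibitor, a higher number a weaker inhibitor), compound 1 gives only a limit, > 3000 nM. For the measured compounds named here, compound 2 `Cc1cccnc1C(=O)NCc1cncc(N2C(=O)c3ccc(Cl)cc3C2(C)C)c1`, a larger molecule with a pyridine-carbonyl amide, gives in this assay a half-maximal inhibitory concentration of 9 nM, and it stands alone as the only compound with a numeric result. Compound 3 `CC(=O)NCc1cncc(N2C(=O)c3ccc(Cl)cc3C2(C)C)c1` differs from compound 2 by methyl in place of 3-methylpyridin-2-yl on a carbonyl carbon. Going by the values given here, no measured pair shows this exact change. The step from compound 2 to compound 3 is expected to weaken inhibition beyond the usual scatter, by a 13-fold higher number from compound 2 to compound 3 (1.12 log units; beyond the scatter). Compound 3 is therefore estimated at 120 nM, most likely between 25 nM and 700 nM.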

Compound 3, half-maximal inhibitory concentration: 59 nM
Estimate against measurement, compound 3: 2.0-fold (0.31 log units) above; the range from low to high includes it.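

Putting methyl in place of 3-methylpyridin-2-yl on this carbonyl carbon gives a 6.6-fold higher number from compound 2 to compound 3 (0.82 log units; beyond the scatter) in this assay. The ring therefore adds to inhibition at this position, yet compound 3 still gives a numeric result, so the simple acetyl cap keeps measurable inhibition without that ring. Nothing measured here gives a reason for this loss.

From the compounds shown here alone, whether a phenyl, a pyridin-2-yl without the methyl, or an ethyl on this carbonyl carbon would come closer to compound 2 or to compound 3 remains open.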